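A few compounds are considered here, and "the series" means these few. Any claim that something is new, unique, unknown or untested is made for them only; others in the source may bear on it.

Series notes on inhibition at a single concentration. Compound 1 `CCCc1nc(-c2ccccc2)c(CNCCN2CCN(c3ccccc3Cl)CC2)o1` gives 60.1% in an assay on HEK293 cells for inhibition of Voltage-dependent T-type calcium channel subunit alpha-1G (Homo sapiens), read by fluorescence, tested at 10 uM; on this read-out lower numbers stand for less inhibition and higher numbers for more inhibition at the one concentration tested (going by the name of the read-out). Compound 2 `CCCc1nc(-c2ccccc2)c(CNCCCN2CCN(c3ccccc3F)CC2)o1` gives 54.4% in this assay, and compound 3 `CCCc1nc(-c2ccccc2)c(CNCCN2CCN(c3ccc(C)cc3)CC2)o1` gives 48.1%. Compound 2 stands second highest of the three numbers: compound 1 is higher by an amount within the scatter, and compound 3 is lower by an amount within the scatter, so on these numbers compound 2 is not separated from either. Among the compounds with values here, the one step measured is a number 12 percentage points lower from compound 1 to compound 3 (beyond the scatter), a modest drop.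

Compound 4 `CCCc1nc(-c2ccccc2)c(CNCCCN2CCN(c3ccc(C(F)(F)F)cc3)CC2)o1` differs from compound 2 by 4-(trifluoromethyl)phenyl in place of 2-fluorophenyl on an amine nitrogen in a ring. Within the data shown here, no measured pair shows this exact exchange; the nearest is the step from compound 1 to compound 3, which also replaced a 2-substituted phenyl on the ring nitrogen with a 4-substituted one and gave a drop beyond the scatter. A step of similar size and direction is therefore expected, a change of a number 9.4 percentage points lower from compound 2 to compound 4 (within the scatter), though with the scatter this is only loosely supported. Compound 4 is estimated at 45% in this assay, within 28% to 62%.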

Compound 4, a percentage reported as inhibition, at one concentration (the size of the read-out at that concentration, not a potency): 51.6%
Compound 4: the middle estimate sits 6.6 percentage points below what was measured; the measured number falls inside the stated range.
By their numbers in this assay, from the lowest: compounds 3, 4, 2 and 1 (each within the scatter of the next, the first and the last beyond it).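

In this assay, a number 2.8 percentage points lower from compound 2 to compound 4 (within the scatter), so on this chain the position on the amine nitrogen in a ring takes 4-(trifluoromethyl)phenyl in place of 2-fluorophenyl without a separable change in the read-out. Moving from a 2-substituted to a 4-substituted phenyl therefore does not by itself go with a drop: a number 12 percentage points lower from compound 1 to compound 3 (beyond the scatter) lay beyond the scatter, but that step has different groups and a different chain, so the two steps cannot be set against each other directly. Nothing at hand accounts for this result.

Open, from the compounds shown here alone, is how 4-(trifluoromethyl)phenyl or 2-fluorophenyl would read on the chain of compound 1, which would separate the effect of the group from that of the chain. Also open, going by these compounds, is how an unsubstituted phenyl or a pyridine ring would read at this position.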